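The compounds below may be only part of what the source reports. "The series", "measured", "known", "first", "only" and "open" are said of these compounds alone.

Measured compounds:
compound 1 `O=C(/C=C/c1ccc2c(c1)B(O)OC2)c1ccc(I)cc1` — > 100000 nM
compound 2 `O=C(/C=C/c1ccc2c(c1)B(O)OC2)c1ccccc1F` — 25400 nM
compound 3 `Cc1cccc(C(=O)/C=C/c2ccc3c(c2)B(O)OC3)c1` — 15900 nM

In a toxicity assay on MCF-10A cells (Homo sapiens) for cytotoxicity, read by MTT assay, with a stated time of 48 h (a higher number here means a weaker inhibitor, a lower number a stronger inhibitor), compound 1 reaches only a limit of the assay, (the limit of > 100000 nM in this assay, at which 1 of the 3 values shown sits), so no number stands for it. Compound 2 gives 25400 nM and compound 3 gives 15900 nM; the two sit within the scatter of each other, a 1.6-fold lower number from compound 2 to compound 3 (0.20 log units; within the scatter). Compound 4 `O=C(O)c1ccc(C(=O)/C=C/c2ccc3c(c2)B(O)OC3)cc1` is unmeasured and differs from compound 1 as follows: carboxy in place of iodo on an aromatic carbon. The steps that start at compound 1 bear on this change: an at least 3.9-fold lower number from compound 1 to compound 2 (0.59 log units; beyond the scatter) and an at least 6.2-fold lower number from compound 1 to compound 3 (0.79 log units; beyond the scatter), each swapping the group on the carbonyl carbon and each lowering the number. For the measured compounds named here, a carboxy group has no counterpart among the measured replacements, so the expectation rests on direction alone and stays loose. Compound 4 is expected to give about 70000 nM (15000 nM to 300000 nM), an expected step of an at least 1.4-fold lower number from compound 1 to compound 4 (0.15 log units; that floor lies within the scatter), with a real chance that this assay again reports only a limit.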

Compound 4, half-maximal inhibitory concentration: > 100000 nM
Compound 4 ended at the assay's limit; the forecaster's own chance of this, stated with the estimate: 50%; middle value at least 1.4-fold (0.15 log units) from the limit.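

Compound 1 and compound 4 both stand only at a limit of the assay in this assay, so no step can be read between them: the limit of > 100000 nM in this assay, at which 2 of the 4 values shown sit.

From the compounds shown here alone, whether carboxy in place of iodo on an aromatic carbon changes the number at all, and by how much, stays open.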